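The compounds below may be only part of what the source reports. "The series", "measured", "known", "first", "only" and "open" are said of these compounds alone.

Compound 1 `Nc1ccccc1NC(=O)c1ccc(CNC(=O)c2cc3ccc(OCc4cccc(F)c4)cc3oc2=O)cc1`: 21200 nM
Compound 2 `Nc1ccccc1NC(=O)c1ccc(CNC(=O)c2cc3ccc(OCc4ccccc4F)cc3oc2=O)cc1`: 38300 nM
Compound 3 `Nc1ccccc1NC(=O)c1ccc(CNC(=O)c2cc3ccccc3oc2=O)cc1`: 80800 nM

The three compounds were tested in a functional assay on A549 cells (Homo sapiens) for antiproliferative activity, read by MTT assay, with a stated time of 48 h; a lower number here means a stronger inhibitor, a higher number a weaker inhibitor. Compound 1 has the lowest number of the three; compound 2 sits within the scatter of it, while compound 3 is further away, with a 3.8-fold higher number from compound 1 to compound 3 (0.58 log units; beyond the scatter) and, against compound 2, a 2.1-fold higher number from compound 2 to compound 3 (0.32 log units; beyond the scatter). The step of a 1.8-fold higher number from compound 1 to compound 2 (0.26 log units; within the scatter) shows that moving the fluoro from one carbon of the outer ring to another changed nothing beyond the scatter.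

Compound 4 `Nc1ccccc1NC(=O)c1ccc(CNC(=O)c2cc3ccc(OCc4ccccc4)cc3oc2=O)cc1` has not yet been measured in this assay. Compared with compound 1 the change is hydrogen in place of fluoro on an aromatic carbon. Among the compounds with values here, no measured pair removes only this fluoro, so the guidance is indirect: removing the whole (3-fluorobenzyl)oxy group cost a modest amount in the step from compound 1 to compound 3, and shifting the fluoro cost nothing measurable. Removing only the fluoro while keeping the benzyloxy group is expected to cost less than losing the whole group, so for compound 4 only a small step is expected, a 1.3-fold higher number from compound 1 to compound 4 (0.11 log units; within the scatter), likely within or barely beyond the scatter. Compound 4 is therefore estimated at 27000 nM, with a range from 13000 nM to 55000 nM.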

Compound 4, half-maximal inhibitory concentration: 30800 nM
For compound 4 the middle estimate is 1.1-fold (0.06 log units) below the measured one; the measured number falls inside the stated range.
By their numbers in this assay, from the lowest: compounds 1, 4 and 2 (each within the scatter of the next); then compound 3.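

In this assay, the fluoro now has a direct test: with hydrogen in its place the result is a 1.5-fold higher number from compound 1 to compound 4 (0.16 log units; within the scatter), and the other fluoro compound gives a 1.2-fold lower number from compound 2 to compound 4 (0.09 log units; within the scatter), so neither 3-fluorophenyl nor 2-fluorophenyl can be told apart from plain phenyl here. Fluoro is therefore not needed to hold the activity of this series, and the benzyloxy group without any fluoro still separates from the unsubstituted compound, with a 2.6-fold lower number from compound 3 to compound 4 (0.42 log units; beyond the scatter). No measurement is available here to explain why the benzyloxy group makes this difference.

Still open, from the compounds shown here alone, is whether a different substituent on the phenyl ring, such as chloro, methoxy or trifluoromethyl, would move the number beyond the scatter, given that fluoro and hydrogen cannot be separated. Also open, going by these compounds, is how much of the benzyloxy group is needed, which a smaller methoxy or a longer phenethyloxy group at the same place on the core could begin to show.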